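Swapping the Group on the Chain Carbon of Compound 1

The source may report more compounds than this note shows. Statements on the series, on what has been measured and on what is new or still open speak of the compounds shown alone.

Compound 1, `COc1ccc(C(=O)/C=C/c2ccc(Br)cc2)c2c1C=CC(C)(C)O2`, in this assay: > 10000 nM
Compound 2, `COc1ccc(C(=O)/C=C/c2ccc(N(c3ccccc3)c3ccccc3)cc2)c2c1C=CC(C)(C)O2`: > 10000 nM
Compound 3, `COc1ccc(C(=O)/C=C/c2ccc3ccccc3n2)c2c1C=CC(C)(C)O2`: 4280 nM

These three compounds share one core and differ only in the group on a double-bonded chain carbon. All were tested in a functional assay on HepG2 cells (Homo sapiens) for antiproliferative activity, read by MTT assay, with a stated time of 24 h; a lower number here means a stronger inhibitor, a higher number a weaker inhibitor. Compound 1 gives only a limit of the assay, > 10000 nM, and not a number. Compound 2 likewise sits at a limit, > 10000 nM. Compound 3 gives a measured number, 4280 nM. Compound 1 thus stands at the limit of > 10000 nM in this assay, at which 2 of the 3 values shown sit, and nothing more precise is known about it. No pair of these compounds differs in a single place, so no measured step exists to guide the next change.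

Compound 4, `COc1ccc(C(=O)/C=C/c2cc(Cl)ccc2O)c2c1C=CC(C)(C)O2`, has not yet been measured. It differs from compound 1 by 5-chloro-2-hydroxyphenyl in place of 4-bromophenyl on a double-bonded chain carbon bound to a double-bonded chain carbon. Among the measured compounds shown here, with no measured step available and compound 1 known only as a limit, the expectation can only be loose. The step of an at least 1.4-fold lower number from compound 1 to compound 4 (0.15 log units; that floor lies within the scatter) is estimated to be a modest gain toward stronger inhibition. Compound 4 is therefore expected to give about 7000 nM, between 1500 nM and 30000 nM, with a fair chance that it is again reported only as a limit.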

Compound 4, half-maximal inhibitory concentration: 6640 nM
The estimate for compound 4 lay 1.1-fold (0.02 log units) above the measured number; measured number inside the range.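

Among the compounds shown here, at this double-bonded chain carbon, 5-chloro-2-hydroxyphenyl in place of 4-bromophenyl gives the only step readable so far in this assay: an at least 1.5-fold lower number from compound 1 to compound 4 (0.17 log units; that floor lies within the scatter). For the compounds shown here, compound 4 shows that a substituted phenyl group on this carbon can give a measured number and not only a limit, something the earlier compounds showed only for compound 3, whose group is not a phenyl. The true size of this step stays unknown, since compound 1 is known only as a limit: the limit of > 10000 nM in this assay, at which 2 of the 4 values shown sit.

The change swaps the bromine for a chlorine and adds a hydroxy group at once, so the compounds shown do not tell which of these parts matters. Also open, going by these compounds, is how a phenyl group carrying only the hydroxy or only the chlorine would read, or one carrying an amine or a carboxylic acid instead.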